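Notes on three measured compounds and one pending analogue

The compounds below may be only part of what the source reports. "The series", "measured", "known", "first", "only" and "open" are said of these compounds alone.

Measured so far:
compound 1 `C=C(Br)C(=O)Nc1cccc(-c2cn3nc(-c4ccc(C)cc4)sc3n2)c1` — 1200 nM
compound 2 `C=C(Br)C(=O)Nc1cccc(-c2cn3c(-c4ccccc4)csc3n2)c1` — 1300 nM
compound 3 `Nc1cccc(-c2cn3nc(-c4ccc(F)cc4)sc3n2)c1` — 33000 nM

In a functional assay on FM3A cells (Mus musculus) for inhibition, read by cell counting, with a stated time of 2 days (on this read-out lower numbers stand for stronger inhibition and higher numbers for weaker inhibition), compound 1 gives 1200 nM, the lowest of the three numbers. Compound 2 gives 1300 nM, which sits within the scatter of compound 1, so the two cannot be ordered. Within the data shown here, compound 3 gives 33000 nM, a number that lies beyond the scatter of compound 1; no single-point step connects compound 3 to either of the other two, so only the two values themselves can be compared.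

The next compound to be measured is compound 4 `C=C(Br)C(=O)Nc1cccc(-c2cn3nc(-c4ccc(CC)cc4)sc3n2)c1`. It differs from compound 1 by methyl in place of hydrogen on a saturated chain carbon bound to an aromatic carbon. Cut one bond further out, the same change reads methyl to ethyl, or 4-methylphenyl to 4-ethylphenyl. Among the measured compounds shown here, no pair of measured compounds shows a change of this kind, so nothing measured here sets the size of the step. A difference this small in the chain is expected to leave the number close to that of compound 1, and the step of a 1.1-fold lower number from compound 1 to compound 4 (0.04 log units; within the scatter) is expected to stay within the scatter, with no direction claimed. Compound 4 is therefore expected to give 1100 nM, with a range from 400 nM to 3000 nM.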

Compound 4, half-maximal inhibitory concentration: 3300 nM
Estimate against measurement, compound 4: 3.0-fold (0.48 log units) below; measured number above the stated range.
By their numbers in this assay, from the lowest: compounds 1 and 2 (each within the scatter of the next); then compound 4; then compound 3.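

In this assay the change from 4-methylphenyl to 4-ethylphenyl gives a 2.8-fold higher number from compound 1 to compound 4 (0.44 log units; beyond the scatter) and so shows that this position is not indifferent to one added methyl on a saturated chain carbon bound to an aromatic carbon. Among these compounds, this is the first step that joins two measured compounds through a single change, and it fixes a size and a direction for this one pair, with weaker inhibition on the 4-ethylphenyl side. Nothing measured on either compound bears on the origin of the step, which stays unexplained.

Open, going by these compounds, is whether the number keeps rising along a longer chain such as propyl or butyl at the same place, and whether a branched isopropyl, a methoxy or a carboxylic acid there would move it in the same direction. Also open, on these data alone, is whether the same methyl to ethyl change gives a step of this size on the core of compound 2, or on compounds carrying the free amine of compound 3.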